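Changing the ring on the doubly bonded carbon

A few compounds are considered here, and "the series" means these few. Any claim that something is new, unique, unknown or untested is made for them only; others in the source may bear on it.

Compound 1 `NS(=O)(=O)c1ccc(Nc2nc(N/N=C/c3ccc(C(F)(F)F)cc3)nc(Nc3ccccc3)n2)cc1` and compound 2 `Cc1nn(-c2ccccc2)cc1/C=N/Nc1nc(Nc2ccccc2)nc(Nc2ccc(S(N)(=O)=O)cc2)n1` share one core and differ only at the carbon with a double bond to nitrogen. In a functional assay on SK-MEL-5 cells (Homo sapiens) for inhibition, read by sulforhodamine B assay, with a stated time of 48 h (a higher number here means a weaker inhibitor of growth, a lower number a stronger inhibitor of growth), compound 1 gives 1740 nM, and in this assay compound 2 gives 1480 nM. The step of a 1.2-fold lower number from compound 1 to compound 2 (0.07 log units; within the scatter) lies within the scatter, so these two numbers cannot be told apart. Compound 3 `NS(=O)(=O)c1ccc(Nc2nc(N/N=C/c3ccccn3)nc(Nc3ccccc3)n2)cc1` carries pyridin-2-yl in place of 3-methyl-1-phenyl-1H-pyrazol-4-yl on a carbon with a double bond to nitrogen. Among the compounds with values here, only the step of a 1.2-fold lower number from compound 1 to compound 2 (0.07 log units; within the scatter) bears on this change, and it was within the scatter, so in this assay the step expected is a 1.0-fold higher number from compound 2 to compound 3 (0.01 log units; within the scatter), nothing beyond the scatter. Compound 3 is estimated at 1500 nM, in a range from 600 nM to 4000 nM.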

Compound 3, concentration for 50% growth inhibition: 780 nM
The estimate for compound 3 lay 1.9-fold (0.28 log units) above the measured number, and the stated range covers the measured number.
By their numbers in this assay, from the lowest: compounds 3, 2 and 1 (each within the scatter of the next, the first and the last beyond it).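

Within the data shown here, at this carbon, pyridin-2-yl gives the first step beyond the scatter, though a modest one (a 2.2-fold lower number from compound 1 to compound 3 (0.35 log units; beyond the scatter)) in this assay, so the ring placed here can change the number. The other step stays within the scatter (a 1.9-fold lower number from compound 2 to compound 3 (0.28 log units; within the scatter)), so compound 2 cannot be told apart from compound 3. Nothing available explains the difference between compound 1 and compound 3. A plain phenyl on this carbon would separate the ring nitrogen of pyridin-2-yl from the loss of trifluoromethyl. An open propyl chain would test whether a ring is needed here at all.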